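Nitro in place of hydrogen: cytotoxicity notes on the series

The source may hold more compounds than are shown below. What is called first, only, known or untested is meant among the compounds shown, and "the series" means these compounds.

Measured so far:
- compound 1 `COc1c(N2CCN(C)C(c3ccccc3)C2)c(F)cc2c(=O)c(C(=O)O)cn(C3CC3)c12` — in an ADME assay on Vero cells (Chlorocebus sabaeus) for cytotoxicity, read by MTT assay, with a stated time of 72 h (a lower number here means a stronger inhibitor, a higher number a weaker inhibitor), the entry for compound 1 reads "not determined" (no result reported)
- compound 2 `COc1c(N2CCC3(CC2)OCCO3)c(F)cc2c(=O)c(C(=O)O)cn(C3CC3)c12` — in this assay compound 2 gives 149000 nM
- compound 3 `COc1c(N2CCN(C(c3ccccc3)c3ccc(Cl)cc3)CC2)c(F)c([N+](=O)[O-])c2c(=O)c(C(=O)O)cn(C3CC3)c12` — in this assay compound 3 gives 103000 nM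

Compound 1 stands on no number of its own in this assay; the only figures in hand come from compound 2 and compound 3, and the two differ in several places, so no single step can be read between them. What their two values show is that both sit in the same broad region of weak cytotoxicity, within the usual scatter of each other, and no word of order between them is warranted.

Compound 4 `COc1c(N2CCN(C)C(c3ccccc3)C2)c(F)c([N+](=O)[O-])c2c(=O)c(C(=O)O)cn(C3CC3)c12` is the next compound to go into this assay. It differs from compound 1 by nitro in place of hydrogen on an aromatic carbon. For the measured compounds named here, no measured pair carries exactly this change, so the size of the step is open. Given that compound 3, which also carries a nitro group, gives 103000 nM, and compound 2, without one, gives 149000 nM, no movement beyond the scatter is expected for compound 4 in either direction.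

Compound 4 is expected to give about 115000 nM in this assay, with a plausible range from 40000 nM to 300000 nM.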

Compound 4, half-maximal inhibitory concentration: 126000 nM
Beside the measured number, compound 4's estimate is 1.1-fold (0.04 log units) below it; measured number inside the range.
By their numbers in this assay, from the lowest: compounds 3, 4 and 2 (each within the scatter of the next).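

Compound 4 differs in one place only from compound 1, which has no single number in this assay, so no new step can be read from the result. The compounds shown leave open the size of the step for nitro in place of hydrogen in this assay. Nothing in hand bears on a cause for the value of compound 4.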